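Hydrazone series: pyridin-2-yl replacing 2,4-dichlorophenyl

The compounds below may be only part of what the source reports. "The series", "measured", "known", "first", "only" and "open" are said of these compounds alone.

Measured so far:
compound 1, `CC1CCC(=NNc2ccc(Cl)cc2Cl)c2ncc(C(=O)O)c(=O)n21`: > 100 umol/kg
compound 2, `CC1CCC(=NNc2cc([N+](=O)[O-])cc([N+](=O)[O-])c2)c2ncc(C(=O)O)c(=O)n21`: > 100 umol/kg

In a functional assay on the whole organism with Rattus norvegicus as the target (a higher number here means that more compound is needed for the effect, a lower number that less compound is needed), compound 1 gives > 100 umol/kg, which is a limit of the assay and not a number. In this assay compound 2 likewise gives > 100 umol/kg, again a limit. Compound 1 therefore stands at the limit of > 100 umol/kg in this assay, at which 2 of the 2 values shown sit, and no measured number places it within the range of the assay. Among the compounds with values here, no step between two measured compounds is known.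

Compound 3, `CC1CCC(=NNc2ccccn2)c2ncc(C(=O)O)c(=O)n21`, differs from compound 1 by pyridin-2-yl in place of 2,4-dichlorophenyl on an amine nitrogen. Since compound 1 is known only as a limit, the step to compound 3 cannot be anchored to a measured value; the expectation is that compound 3 will also sit at or near the limit, with no step beyond the scatter. Compound 3 is expected at 100 umol/kg, with a range from 30 umol/kg to 300 umol/kg. The estimated step of a number no higher from compound 1 to compound 3 (the limit leaves the size open) is taken as none beyond the scatter.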

Compound 3, dose for 50% inhibition: > 100 umol/kg
Compound 3: only a limit was reported; the forecaster's own chance of this, stated with the estimate: 70%; the middle value lies on the limit itself.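

In this assay compound 3 gives > 100 umol/kg, which is a limit and not a number. No step from compound 1 to compound 3 can be read: the limit of > 100 umol/kg in this assay, at which 3 of the 3 values shown sit.

The compounds shown leave open whether pyridin-2-yl in place of 2,4-dichlorophenyl changes the dose needed at all.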